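From a Free Amino Group to a Cyclopropyl Amide

A few compounds are considered here, and "the series" means these few. Any claim that something is new, unique, unknown or untested is made for them only; others in the source may bear on it.

Values in a functional assay on A549 cells (Homo sapiens) for antiproliferative activity, read by MTT assay, with a stated time of 48 h; on this read-out lower numbers stand for stronger inhibition and higher numbers for weaker inhibition:
- Compound 1 `Cn1cc(-c2cnc3ccnc(N)c3c2)cn1`: 33400 nM
- Compound 2 `Cn1cc(-c2cnc3ccc(NS(=O)(=O)c4cccs4)nc3c2)cn1`: 39500 nM
- Compound 3 `Cn1cc(-c2cnc3ccc(NS(=O)(=O)c4ccc(Cl)cc4Cl)nc3c2)cn1`: > 50000 nM. This is a limit of the assay and not a number.

Among the compounds with values here, compound 1 lies within the usual scatter of compound 2, the only other compound here with an exact number. Compound 4 `Cn1cc(-c2cnc3ccnc(NC(=O)C4CC4)c3c2)cn1` carries cyclopropylcarbonyl in place of hydrogen on a nitrogen on an aromatic ring.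

Within the data shown here, the only measured step is an at least 1.2-fold higher number from compound 2 to compound 3 (0.10 log units; that floor lies within the scatter). It comes from 2,4-dichlorophenyl in place of thiophen-2-yl on a sulfonyl sulfur, so it concerns a different group and offers only a loose guide. Among the measured compounds shown here, no measured step starts from compound 1, and none adds a cyclopropylcarbonyl group. With so little to go on, no step beyond the scatter is expected in this assay.

The estimate is a 1.0-fold higher number from compound 1 to compound 4 (0.02 log units; within the scatter). Compound 4 is expected at 35000 nM, with an estimated range of 15000 nM to 50000 nM.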

Compound 4, half-maximal inhibitory concentration: > 50000 nM
Compound 4: no number, only a limit; the forecaster's own chance of this, stated with the estimate: 25%; middle value at least 1.4-fold (0.15 log units) from the limit.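

Compound 4 gives > 50000 nM in this assay, which is a limit of the assay and not a number. This is the first change shown on the free amino group of compound 1, and putting cyclopropylcarbonyl in place of its hydrogen gives an at least 1.4-fold higher number from compound 1 to compound 4 (0.17 log units; that floor lies within the scatter), so the amide shows no gain in inhibition over the free amine. How far the true value of compound 4 lies from that of compound 1 cannot be read: the limit of > 50000 nM in this assay, at which 2 of the 4 values shown sit.

The compounds shown leave open whether a smaller acyl group such as acetyl, a plain methyl group or a longer carbon chain on this nitrogen would give a lower number than the free amino group. They also leave open whether a carboxylic acid or an amine attached to the cyclopropane ring would change the picture.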